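Methyl to phenyl on a quinolinylmethoxy-aryl chain

The source may report more compounds than this note shows. Statements on the series, on what has been measured and on what is new or still open speak of the compounds shown alone.

Three compounds built around a quinolinylmethoxy-substituted benzene were measured in an assay on membranes from lung (Cavia porcellus) for binding affinity to cysteinyl leukotriene receptor (Homo sapiens); on this read-out higher numbers stand for weaker inhibition and lower numbers for stronger inhibition. Compound 1 `CC(CCC(=O)O)Cc1cccc(OCc2ccc3ccccc3n2)c1` carries a carboxylic acid chain with a methyl branch; in this assay compound 1 gives 140 nM. Compound 3 `O=C(O)CCC(Cc1cccc(OCc2ccc3ccccc3n2)c1)c1ccccc1` is its direct relative, differing by phenyl in place of methyl on a saturated chain carbon bound to two saturated chain carbons; in this assay compound 3 gives 52 nM. That single change produced a 2.7-fold lower number from compound 1 to compound 3 (0.43 log units; beyond the scatter).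

Compound 2 `CC(CCc1nnn[nH]1)Cc1ccc(OCc2ccc3ccccc3n2)cc1` replaces the acid with a tetrazole and shifts the substitution pattern of the central ring; in this assay compound 2 gives 12 nM, the lowest of the three numbers, and its steps to compound 3 and compound 1 both lie beyond the usual scatter. The difference between the cores of compound 1 and compound 2 is not broken down here.

Compound 4 `c1ccc(C(CCc2nnn[nH]2)Cc2ccc(OCc3ccc4ccccc4n3)cc2)cc1` has not yet been measured. It differs from compound 2 by phenyl in place of methyl on a saturated chain carbon bound to two saturated chain carbons, the same change, at the same place, that separates compound 1 from compound 3. Since that step was a 2.7-fold lower number from compound 1 to compound 3 (0.43 log units; beyond the scatter), a step of similar size is expected for compound 4, namely a 2.4-fold lower number from compound 2 to compound 4 (0.38 log units; beyond the scatter) from compound 2, though the cores of compound 2 and compound 1 differ in ways not broken down here, so the transfer is uncertain. In this assay compound 4 is therefore estimated at 5 nM, with a plausible range from 2 nM to 15 nM.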

Compound 4, inhibition constant: 8 nM
For compound 4 the middle estimate is 1.6-fold (0.20 log units) below the measured one; low and high end bracket the measured number.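

In this assay, the move from methyl to phenyl on a saturated chain carbon bound to two saturated chain carbons gives a 1.5-fold lower number from compound 2 to compound 4 (0.18 log units; within the scatter), so on this core the step cannot be told apart from repeat measurement, whereas on the other core it was a 2.7-fold lower number from compound 1 to compound 3 (0.43 log units; beyond the scatter). Even so, the two steps do not differ from each other in any way these data can resolve: the same change on two cores in this assay, a 2.7-fold lower number (0.43 log units; beyond the scatter) from compound 1 to compound 3 and a 1.5-fold lower number (0.18 log units; within the scatter) from compound 2 to compound 4, 1.8-fold (0.25 log units) apart, within the scatter of two such steps

Going by these compounds alone, this shows that the change carried from one core to the other without a detectable difference in size, but it does not show that the step is the same on both, since only two cores are compared and the second step alone stays within the scatter. It also cannot be said that the change gives a real gain on every core in this series.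

The compounds shown leave open how a cyclohexyl ring, a benzyl group or an amine on that same chain carbon would read out in this assay. They also leave open how much of the gap between the two cores belongs to the tetrazole in place of the carboxylic acid and how much to the shifted substitution on the central ring, as those two differences always occur together here.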